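This account rests on a few compounds, and the source may have more. Where it says the series, first, only, none or still open, it means among the compounds named here.

Three compounds have been measured in a functional assay on SR cells (Homo sapiens) for inhibition, read by sulforhodamine B assay, with a stated time of 48 h; on this read-out lower numbers stand for stronger inhibition of growth and higher numbers for weaker inhibition of growth:

Compound 1 `COc1cc(-c2nn(-c3cccc(NC(=O)Nc4cc(C(F)(F)F)cc(C(F)(F)F)c4)c3)cc2-c2ccncc2)ccc1Cl` gives 3970 nM.
Compound 2 `O=C(Nc1cccc(-n2cc(-c3ccncc3)c(-c3ccc(Cl)c(O)c3)n2)c1)Nc1cc(C(F)(F)F)cc(C(F)(F)F)c1` gives 3660 nM.
Compound 3 `COc1cc(-c2nn(-c3cccc(NC(=O)Nc4ccc(Cl)c(C(F)(F)F)c4)c3)cc2-c2ccncc2)ccc1Cl` gives 2480 nM.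

Compound 1 and compound 2 differ in one place only, (hydrogen in place of methyl on an oxygen on an aromatic ring). That change produced a 1.1-fold lower number from compound 1 to compound 2 (0.04 log units; within the scatter), so the two numbers show no real separation. Compound 3 carries a different urea-bearing part than compound 1; the difference between the two cores is not broken down here. Its value sits within the scatter of both compound 1 and compound 2.

Compound 4 `O=C(Nc1cccc(-n2cc(-c3ccncc3)c(-c3ccc(Cl)c(O)c3)n2)c1)Nc1ccc(Cl)c(C(F)(F)F)c1` has not yet been measured. It stands to compound 3 as compound 2 stands to compound 1: the same change, (hydrogen in place of methyl on an oxygen on an aromatic ring), at the same place on the same ring. Because the earlier instance gave a 1.1-fold lower number from compound 1 to compound 2 (0.04 log units; within the scatter), the change is expected to do little here as well, with an estimated 1.1-fold lower number from compound 3 to compound 4 (0.03 log units; within the scatter) in this assay. Compound 4 is therefore expected to give about 2300 nM, most likely between 1200 nM and 4600 nM.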

Compound 4, concentration for total growth inhibition: 2520 nM
Beside the measured number, compound 4's estimate is 1.1-fold (0.04 log units) below it, and the stated range covers the measured number.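

Changing methoxy to hydroxy on the second core gives a 1.0-fold higher number from compound 3 to compound 4 (0.01 log units; within the scatter) in this assay, so this swap leaves the growth-inhibition number where it was. Set beside the earlier case, the same change behaves alike on both cores: the same change on two cores in this assay, a 1.1-fold lower number (0.04 log units; within the scatter) from compound 1 to compound 2 and a 1.0-fold higher number (0.01 log units; within the scatter) from compound 3 to compound 4, 1.1-fold (0.04 log units) apart, within the scatter of two such steps

Among these compounds, this means that, across these four compounds, the result from one core carried over to the other, but it rests on only two pairs in a single cell assay, and the two cores differ only in the urea-bearing part, so it cannot be stretched to more distant cores or to other assays. Among the compounds shown here, it also shows only that the swap made no visible difference here, and gives no explanation for that.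

The compounds shown leave open whether a longer chain on that oxygen, such as ethoxy, or an amine in place of the hydroxy would move the number beyond the scatter. They also leave open whether the swap stays this quiet when the urea-bearing part carries a carboxylic acid.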